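Shifting and alkylating the amine on the alkyne chain

The source may report more compounds than this note shows. Statements on the series, on what has been measured and on what is new or still open speak of the compounds shown alone.

Compound 1 `COc1cc[nH]c1/C=C1\C(=O)Nc2ccc(F)c(C#CC(O)CN)c21`: 130 nM
Compound 2 `COc1cc[nH]c1/C=C1\C(=O)Nc2ccc(F)c(C#C[C@H](N)CO)c21`: 320 nM
Compound 3 `COc1cc[nH]c1/C=C1\C(=O)Nc2ccc(F)c(C#C[C@H](CO)NCCO)c21`: 1270 nM

All three share one core and differ only in the chain on a triple-bonded carbon; in a functional assay on MDA-MB-435 cells (Homo sapiens) for inhibition (on this read-out lower numbers stand for stronger inhibition and higher numbers for weaker inhibition), compound 1 gives the lowest number of the three. Compound 4 `CCN[C@H](C#Cc1c(F)ccc2c1/C(=C/c1[nH]ccc1OC)C(=O)N2)[C@@H](C)O` is not yet measured and differs from compound 1 by 1-(ethylamino)-2-hydroxypropyl in place of 2-amino-1-hydroxyethyl on a triple-bonded carbon. Within the data shown here, two measured steps bear on it: 1-amino-2-hydroxyethyl in place of 2-amino-1-hydroxyethyl gave a 2.5-fold higher number from compound 1 to compound 2 (0.39 log units; beyond the scatter), and a substituent on that nitrogen gave a 4.0-fold higher number from compound 2 to compound 3 (0.60 log units; beyond the scatter), the two together amounting to a 9.8-fold higher number from compound 1 to compound 3 (0.99 log units; beyond the scatter). Compound 4 combines both kinds of change, so weaker inhibition is expected, roughly a 6.9-fold higher number from compound 1 to compound 4 (0.84 log units; beyond the scatter). Compound 4 is estimated at 900 nM, within 300 nM to 2700 nM.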

Compound 4, half-maximal inhibitory concentration: 1070 nM
Compound 4: middle estimate off by 1.2-fold (0.08 log units), on the low side; the range from low to high includes it.
By their numbers in this assay, from the lowest: compound 1; then compound 2; then compounds 4 and 3 (each within the scatter of the next).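

In this assay, compound 4 and compound 3 cannot be told apart (a 1.2-fold lower number from compound 3 to compound 4 (0.07 log units; within the scatter)), although their nitrogen substituents differ, ethyl against 2-hydroxyethyl. Compound 4 also stays clearly behind both compounds with an unsubstituted amine (a 3.3-fold higher number from compound 2 to compound 4 (0.52 log units; beyond the scatter); an 8.2-fold higher number from compound 1 to compound 4 (0.92 log units; beyond the scatter)), so in these compounds both substituted amines give higher numbers. No measurement here explains this.

As far as these compounds go, compound 4 changes the nitrogen substituent and adds a methyl on the chain, so the share of each remains open. So does the outcome with a dimethylamine or a carboxylic acid on this chain.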